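The source may report more compounds than this note shows. Statements on the series, on what has been measured and on what is new or still open speak of the compounds shown alone.

Compound 3 `CC#C[C@@H](CC(=O)O)c1ccc(OC[C@H]2COc3ccc(F)cc3O2)cc1` sits in the middle of a small set measured in a functional assay on HEK293 cells for agonist activity at Free fatty acid receptor 1 (Homo sapiens), read by fluorescence and calcium flux, with a stated time of 10 min; on this read-out lower numbers stand for an effect already at smaller amounts and higher numbers for an effect only at larger amounts of compound. Compound 3 gives 210 nM, the second highest of the three numbers. Within the data shown here, its nearest neighbour is compound 2 `CC#C[C@@H](CC(=O)O)c1ccc(OC[C@H]2COc3ccccc3O2)cc1`, which in this assay gives 90 nM; the only measured step with one change, a 2.3-fold higher number from compound 2 to compound 3 (0.37 log units; beyond the scatter), is the one that leads from compound 2 to compound 3, a fluoro in place of hydrogen on an aromatic carbon. Furthest away is compound 1 `Cn1nncc1C(CC(=O)O)c1ccc(OCC2COc3ccc(Cl)cc3O2)cc1`, which in this assay gives 3870 nM; compound 1 carries a chloro on the same fused ring but differs from compound 3 in more than one place, so the two values show only that compound 1 lies far above.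

Compound 4 `CC#C[C@@H](CC(=O)O)c1ccc(OC[C@H]2COc3ccc(Br)cc3O2)cc1` is the next member. It differs from compound 3 by bromo in place of fluoro on an aromatic carbon. Among the measured compounds shown here, no measured pair isolates a bromo for a fluoro at this place; the only step that bears on it is the modest one from compound 2 to compound 3, where a halogen first entered this ring. A halogen is again present, merely exchanged for another, so the estimated step of a 1.2-fold higher number from compound 3 to compound 4 (0.09 log units; within the scatter) is expected to be small and may not leave the scatter. Compound 4 is therefore estimated at 260 nM, with a range from 100 nM to 700 nM.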

Compound 4, half-maximal effective concentration: 210 nM
For compound 4 the middle estimate is 1.2-fold (0.09 log units) above the measured one, within the range that was stated.
By their numbers in this assay, from the lowest: compound 2; then compounds 3 and 4 (each within the scatter of the next); then compound 1.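

The exchange of fluoro for bromo on this aromatic carbon gives no change at the digits printed from compound 3 to compound 4 (within the scatter) in this assay, so at this place the two halogens cannot be told apart, although until now only fluoro had been seen here. Bromo in place of hydrogen gives a 2.3-fold higher number from compound 2 to compound 4 (0.37 log units; beyond the scatter), a step of the same printed size as a 2.3-fold higher number from compound 2 to compound 3 (0.37 log units; beyond the scatter), so for these two halogens the modest shift goes with a halogen being present on this carbon and does not differ with which of the two it is. No measurement shown here offers an explanation for this result.

From the compounds shown here alone, whether a methoxy group, a nitrile or an amine on this aromatic carbon would follow the two halogens or depart from them stays open, and so does the effect of chloro on the shared core, since chloro appears only in compound 1, which differs from the others in more than one place. The compounds also leave open whether fluoro or bromo on another carbon of the same aromatic ring would give a step of similar size.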